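Halogens moved to the other aromatic ring

The source may hold more compounds than are shown below. What is called first, only, known or untested is meant among the compounds shown, and "the series" means these compounds.

Compounds measured so far in a functional assay on DU-145 cells (Homo sapiens) for cytotoxicity, read by MTT assay; on this read-out lower numbers stand for stronger inhibition and higher numbers for weaker inhibition:
compound 1, `CC(O)(CSc1ccc(Cl)cc1)c1nc(-c2ccccc2)no1`, gives 70700 nM.
compound 2, `CC(O)(CSc1ccc(F)cc1)c1nc(-c2ccccc2)no1`, gives only a limit of the assay, > 100000 nM.
compound 3, `CC(O)(CSc1ccccc1)c1nc(-c2ccccc2)no1`, likewise gives only a limit, > 100000 nM.

Compound 3 therefore stands at the limit of > 100000 nM in this assay, at which 2 of the 3 values shown sit, with no number of its own. Compound 4, `CC(O)(CSc1ccccc1)c1nc(-c2ccc(F)c(Cl)c2)no1`, differs from it by 3-chloro-4-fluorophenyl in place of phenyl on an aromatic carbon. The steps seen so far, an at least 1.4-fold higher number from compound 1 to compound 2 (0.15 log units; that floor lies within the scatter) and an at least 1.4-fold higher number from compound 1 to compound 3 (0.15 log units; that floor lies within the scatter), concern halogens on the other aromatic ring, and a step that the two limits leave unreadable from compound 2 to compound 3 cannot be read; none touches the ring changed here. No step beyond the scatter is expected, so compound 4 is estimated at 90000 nM, between 30000 nM and 250000 nM, a step of an at least 1.1-fold lower number from compound 3 to compound 4 (0.04 log units; that floor lies within the scatter) that is itself an expectation only.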

Compound 4, half-maximal inhibitory concentration: 5500 nM
Estimate against measurement, compound 4: 16-fold (1.21 log units) above; the measured number lies below the stated range.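

Putting 3-chloro-4-fluorophenyl in place of phenyl gives an at least 18-fold lower number from compound 3 to compound 4 (1.25 log units; beyond the scatter) in this assay, the first step beyond the scatter among the compounds shown. The ring on the carbon between two ring nitrogen atoms therefore responds to substitution, whereas the halogen changes on the other aromatic ring gave only floors within the scatter. The true size of the step remains unknown, because compound 3 has no number of its own: the limit of > 100000 nM in this assay, at which 2 of the 4 values shown sit.

From the compounds shown here alone, compound 4 carries both halogens at once, so the share of the chloro and the fluoro group stays open. Going by these compounds, whether a methoxy group or an amine on this ring would give a similar step also remains open.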